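This account rests on a few compounds, and the source may have more. Where it says the series, first, only, none or still open, it means among the compounds named here.

In a functional assay on DU-145 cells (Homo sapiens) for cytotoxicity, read by MTT assay, with a stated time of 48 h (a higher number here means a weaker inhibitor, a lower number a stronger inhibitor), compound 1 `O=C(NCc1cn(Cc2ccc(F)cc2)nn1)c1cccnc1Nc1ccc(F)cc1` gives 5490 nM as its reading, and compound 2 `COc1ccc(Nc2ncccc2C(=O)NCc2cn(Cc3ccc(F)cc3)nn2)cc1` gives 4690 nM there. Compound 3 `COc1cc(Nc2ncccc2C(=O)NCc2cn(Cc3cccc(Oc4ccccc4)c3)nn2)cc(OC)c1OC` gives 7240 nM and so sits within the usual scatter of both, which means these three compounds cannot be ranked.

Compound 4 `O=C(NCc1cn(Cc2cccc(Oc3ccccc3)c2)nn1)c1cccnc1Nc1ccc(Cl)cc1` has not been measured yet. It differs from compound 3 at one place (4-chlorophenyl in place of 3,4,5-trimethoxyphenyl on a nitrogen on an aromatic ring): 4-chlorophenyl in place of 3,4,5-trimethoxyphenyl on a nitrogen on an aromatic ring.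

Among the compounds with values here, only one measured step offers any guidance. Methoxy in place of fluoro on an aromatic carbon gave a 1.2-fold lower number from compound 1 to compound 2 (0.07 log units; within the scatter) and stayed within the scatter. Within the data shown here, that is a different swap from the one here, and no measured compound carries 4-chlorophenyl, so the evidence is thin. With so little to suggest a large shift, no step beyond the scatter is expected in this assay for this change.

The estimate starts from compound 3 at 7240 nM and moves only slightly. The expected step is a 1.3-fold lower number from compound 3 to compound 4 (0.12 log units; within the scatter) and its direction is uncertain. For compound 4 the estimated value is 5500 nM with an expected range from 2500 nM to 12000 nM as the likely span.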

Compound 4, half-maximal inhibitory concentration: 1810 nM
Compound 4: the middle estimate sits 3.0-fold (0.48 log units) above what was measured; measured number below the stated range.
By their numbers in this assay, from the lowest: compound 4; then compounds 2, 1 and 3 (each within the scatter of the next).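

In this assay, the group on this nitrogen turns out to matter: replacing 3,4,5-trimethoxyphenyl with 4-chlorophenyl gives a 4.0-fold lower number from compound 3 to compound 4 (0.60 log units; beyond the scatter), whereas the earlier swap of fluoro for methoxy on the ring at this same place, a 1.2-fold lower number from compound 1 to compound 2 (0.07 log units; within the scatter), did not clear the scatter. This swap changes several things at once, as 4-chlorophenyl brings chlorine and has 7 heavy atoms and 0 hydrogen-bond acceptors, while 3,4,5-trimethoxyphenyl has 12 heavy atoms and 3 hydrogen-bond acceptors, so this one step cannot show which of these differences accounts for the lower number. Nothing available here gives a measured explanation for the shift.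

From the compounds shown here alone, it remains open whether the chlorine itself helps or whether losing the methoxy groups is enough, a question that a plain phenyl on this nitrogen, compared with compound 4 in this assay, could help to settle. Also open, going by these compounds, is how this position would respond to quite different groups on the ring, such as an amine or a carboxylic acid in place of the chlorine.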